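This account rests on a few compounds, and the source may have more. Where it says the series, first, only, none or still open, it means among the compounds named here.

Measured compounds:
compound 1 `CCS[C@@H]1[C@H](SCC)[C@@H](Cn2cc(-c3ccc(C)cc3)nn2)O[C@H]1n1ccc(=O)[nH]c1=O` — >= 100000 nM
compound 2 `CCOC(=O)c1cn(C[C@H]2O[C@@H](n3ccc(=O)[nH]c3=O)[C@H](SCC)[C@@H]2SCC)nn1` — >= 100000 nM

Both compounds share one core and differ only in the group on an aromatic carbon of that core. In a functional assay on LAC cells (Homo sapiens) for cytotoxicity, read by MTT assay, with a stated time of 72 h (on this read-out higher numbers stand for an effect only at larger amounts of compound and lower numbers for an effect already at smaller amounts), compound 1 gives >= 100000 nM, which is a limit of the assay and not a number. In this assay compound 2 gives >= 100000 nM, again a limit rather than a measured number. The step that the two limits leave unreadable from compound 1 to compound 2 therefore cannot be read, because both values sit at the limit of >= 100000 nM in this assay, at which 2 of the 2 values shown sit. Compound 2 thus stands at the edge of what the assay reports, with no number of its own.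

Compound 3 `CCS[C@@H]1[C@H](SCC)[C@@H](Cn2cc(-c3cccs3)nn2)O[C@H]1n1ccc(=O)[nH]c1=O` carries the change (thiophen-2-yl in place of ethoxycarbonyl on an aromatic carbon). Among the measured compounds shown here, the one measured step touches the same aromatic carbon, but its size is not readable, so it gives no direction for this change either. For the measured compounds named here, nothing among the measured values points to a shift beyond the scatter, and the most plausible outcome is that compound 3 also ends at the limit. Compound 3 is therefore estimated at 100000 nM, with a range from 30000 nM to 300000 nM. The expected step is a number no higher from compound 2 to compound 3 (the limit leaves the size open), which is taken to be no change beyond the scatter.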

Compound 3, half-maximal effective concentration: 86500 nM
Beside the measured number, compound 3's estimate is 1.2-fold (0.06 log units) above it; measured number inside the range.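

In this assay, among the compounds shown here, compound 3 gives 86500 nM, the first real number at this position, an aromatic carbon of a five-membered aromatic ring with 3 nitrogen, and it comes with thiophen-2-yl on that carbon. The change reads as an at least 1.1-fold lower number from compound 2 to compound 3 (0.06 log units; that floor lies within the scatter), and the exchange of 4-methylphenyl for the same group reads as an at least 1.1-fold lower number from compound 1 to compound 3 (0.06 log units; that floor lies within the scatter), so each step is bounded on one side only and neither bound goes beyond the scatter. The step between compound 1 and compound 2 cannot be read, and the true size of the two new steps stays open as well, because the partners of compound 3 in them give no number: the limit of >= 100000 nM in this assay, at which 2 of the 3 values shown sit.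

The compounds shown leave open whether thiophen-2-yl truly differs from ethoxycarbonyl or 4-methylphenyl here, or whether all three lie close together at the weak end of this read-out. They also leave open what an amine, a carboxylic acid or a longer alkyl chain on this same aromatic carbon would give in this assay, and whether any group at this position can bring the number far from the limit.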